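A few compounds are considered here, and "the series" means these few. Any claim that something is new, unique, unknown or untested is made for them only; others in the source may bear on it.

Compound 2 `CCOC(=O)CCCCCOc1cccc(CN(C(=O)c2ccccc2)C(C)C)c1` is a benzamide carrying the ethyl ester chain. In an ADME assay on HEK293 cells (Homo sapiens) for cytotoxicity, read by CellTiter-Glo and resazurin assay, with a stated time of 72 h (a higher number here means that more compound is needed for the effect, a lower number that less compound is needed), compound 2 reports only a limit, > 26000 nM. Compound 1 `CC(C)N(Cc1cccc(OCCCCCC(=O)O)c1)C(=O)c1ccc(-c2cccc(N(C)C)c2)cc1`, which already bears the biaryl, likewise gives only a limit, > 26000 nM. The two values sit at a common limit (the limit of > 26000 nM in this assay, at which 2 of the 2 values shown sit), so compound 2 stands where everything shown so far stands. Compound 3 `CCOC(=O)CCCCCOc1cccc(CN(C(=O)c2ccc(-c3cccc(N(C)C)c3)cc2)C(C)C)c1` differs from compound 2 by 3-(dimethylamino)phenyl in place of hydrogen on an aromatic carbon. No change beyond the scatter is expected in this assay, since compound 1 with the same biaryl remains at the limit with > 26000 nM. Compound 3 is therefore estimated at 30000 nM (range 10000 nM to 100000 nM), a step that the limit leaves unreadable from compound 2 to compound 3 expected to be nothing beyond scatter.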

Compound 3, half-maximal effective concentration: > 26000 nM
Compound 3: a limit, no number; the forecaster's own chance of this, stated with the estimate: 80%; the middle value does not contradict the limit.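

Among the compounds shown here, compound 3, like compound 1 and compound 2, gives only a limit, so no step from compound 1 or compound 2 to compound 3 can be read: the limit of > 26000 nM in this assay, at which 3 of the 3 values shown sit. The compounds shown leave open what concentration, if any, gives a measurable effect in this assay.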